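The source may report more compounds than this note shows. Statements on the series, on what has been measured and on what is new or still open speak of the compounds shown alone.

Compound 2 `OC[C@@H]1CCCN1c1ncnc2sc(Nc3ccc(Cl)cc3)nc12` has the lower of the two numbers recorded in an assay on CHO cells for displacement of a labelled ligand from adenosine receptor A3 (Homo sapiens), read by scintillation counting, with a stated time of 3 h (a higher number here means a weaker inhibitor, a lower number a stronger inhibitor), with compound 2 giving 934 nM. Compound 1 `Clc1ncnc2sc(Nc3cccc(Br)c3)nc12` gives 3900 nM in this assay. Compound 3 `OC[C@@H]1CCCN1c1ncnc2sc(Nc3cccc(Br)c3)nc12` differs from compound 2 by 3-bromophenyl in place of 4-chlorophenyl on a nitrogen on an aromatic ring. Within the data shown here, no measured pair shows this change on its own, so nothing here tells how large its effect is. A step from compound 2 to compound 3 of about a 1.4-fold higher number from compound 2 to compound 3 (0.14 log units; within the scatter) is expected, with no clear direction beyond the usual scatter. Compound 3 is therefore estimated at 1300 nM, in a range from 400 nM to 4500 nM.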

Compound 3, inhibition constant: 1070 nM
Compound 3: middle estimate off by 1.2-fold (0.08 log units), on the high side; the range from low to high includes it.
By their numbers in this assay, from the lowest: compounds 2 and 3 (each within the scatter of the next); then compound 1.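

In this assay, 3-bromophenyl in place of 4-chlorophenyl on a nitrogen on an aromatic ring gives a 1.1-fold higher number from compound 2 to compound 3 (0.06 log units; within the scatter), so this swap leaves no measurable mark, although halogen and ring position change together. With 3-bromophenyl held constant, 2-(hydroxymethyl)pyrrolidin-1-yl in place of chloro on an aromatic carbon gives a 3.6-fold lower number from compound 1 to compound 3 (0.56 log units; beyond the scatter), a modest gain in strength beyond the scatter. No measurement shown gives a reason for either step.

As far as these compounds go, the separate effects of the halogen and of its ring position remain open. So does the effect of a plain pyrrolidine without the hydroxymethyl, or of a methoxy group on the phenyl ring.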